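A Longer Chain on Compound 3

The compounds below may be only part of what the source reports. "The series", "measured", "known", "first", "only" and "open" are said of these compounds alone.

In a functional assay on cells (Homo sapiens) for antiproliferative activity, read by sulforhodamine B assay, with a stated time of 48 h (a higher number here means a weaker inhibitor, a lower number a stronger inhibitor), compound 3 `CCCCCCCCCCCCCCNC(=O)[C@@H]1CSC(c2ccccc2)N1` gives 1900 nM, within the scatter of both compound 1 `CCCCCCCCCCCCCCCCNC(=O)[C@@H]1CSC(c2cc(OC)c(OC)c(OC)c2)N1` at 1800 nM and compound 2 `CCCCCCCCCCCCCCCCNC(=O)[C@@H]1CSC(c2ccc(NC(C)=O)cc2)N1` at 2100 nM. Compound 4 `CCCCCCCCCCCCCCCCNC(=O)[C@@H]1CSC(c2ccccc2)N1` differs from compound 3 in the chain alone: ethyl in place of hydrogen on a saturated chain carbon, ten or more bonds along the chain from an amide-type nitrogen. Going by the values given here, the only measured step, a 1.2-fold higher number from compound 1 to compound 2 (0.07 log units; within the scatter), lies within the scatter, but it concerns a different place and bears only indirectly. Among the compounds with values here, no measured step isolates the chain change. Still, compound 4 has the chain of compound 1 and compound 2, whose values lie within the scatter of that of compound 3. No change beyond the scatter is therefore expected, and the estimated step is a 1.1-fold lower number from compound 3 to compound 4 (0.05 log units; within the scatter). Compound 4 is expected at about 1700 nM, within an estimated range of 900 nM to 3200 nM.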

Compound 4, half-maximal inhibitory concentration: 1900 nM
Compound 4: the middle estimate sits 1.1-fold (0.05 log units) below what was measured; measured number inside the range.
By their numbers in this assay, from the lowest: compounds 1, 3, 4 and 2 (each within the scatter of the next).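

In this assay, going by these compounds alone, the chain change gives no change at the digits printed from compound 3 to compound 4 (within the scatter), so ethyl in place of hydrogen at this far point of the saturated chain moves the number by nothing beyond the scatter, which no earlier step could show. With the longer chain held, the aromatic group gives the same picture: a 1.1-fold lower number from compound 2 to compound 4 (0.04 log units; within the scatter) for hydrogen in place of acetamido and a 1.1-fold higher number from compound 1 to compound 4 (0.02 log units; within the scatter) for phenyl in place of 3,4,5-trimethoxyphenyl. No evidence bears on this result. The compounds shown leave open whether an octyl chain, or a chain carrying a carboxylic acid, would keep these numbers.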